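From a chlorophenyl amide to a hydroxyacetamide

The source may hold more compounds than are shown below. What is called first, only, known or untested is meant among the compounds shown, and "the series" means these compounds.

The series shares the core shown in compound 1 `C#CCNC1CCc2c(OCCc3cc(NC(C)=O)ccc3Cl)cccc21` and varies the amide on the aryl ring. In an ADME assay on cells for inhibition of Amine oxidase [flavin-containing] A (Homo sapiens), read by fluorescence and Amplex Red, with stated times of 30 min and 15 min (a higher number here means a weaker inhibitor, a lower number a stronger inhibitor), compound 1 gives 85200 nM. Compound 2 `C#CCNC1CCc2c(OCCc3cc(NC(=O)c4ccccc4)ccc3Cl)cccc21` carries a benzoyl group in place of the acetyl group, and in this assay compound 2 gives "not determined" (no result reported), so no result is reported for it. Compound 3 `C#CCNC1CCc2c(OCCc3cc(NC(=O)c4ccc(Cl)cc4)ccc3Cl)cccc21` carries a 4-chlorophenyl group on the carbonyl carbon, and in this assay compound 3 gives "not determined" (no result reported), so compound 3 stands without a number, alongside the one further entry that also lacks one.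

Compound 4 `C#CCNC1CCc2c(OCCc3cc(NC(=O)CO)ccc3Cl)cccc21` differs from compound 3 in one place: hydroxymethyl in place of 4-chlorophenyl on a carbonyl carbon. Going by the values given here, no step between measured compounds is known for this pair, and with compound 3 unmeasured the size of the step cannot be set against a starting value; what remains as a guide is the acetyl analogue compound 1 with 85200 nM, whose small amide resembles the hydroxyacetamide of compound 4 more closely than the aryl amides do. On that basis compound 4 is expected to stay a weak inhibitor in this assay. Compound 4 is estimated at 100000 nM, with a range from 30000 nM to 300000 nM.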

Compound 4, half-maximal inhibitory concentration: 252000 nM
Estimate against measurement, compound 4: 2.5-fold (0.40 log units) below; the measured number falls inside the stated range.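

In this assay, the change of hydrogen to hydroxy on the saturated chain carbon bound to the carbonyl carbon gives a 3.0-fold higher number from compound 1 to compound 4 (0.47 log units; beyond the scatter), a modest step beyond the usual scatter, so compound 4 is a weaker inhibitor than the acetyl analogue. Going by these compounds alone, this gives the first reading at this position, showing that the number responds to a change on the small amide chain and that, in this single pair, hydroxy moves it towards weaker inhibition. No evidence is at hand on why hydroxy has this effect, and the step from compound 3 to compound 4, like any other step involving the two aryl amides, cannot be read.

The compounds shown leave open whether the direction of this step is particular to hydroxy or would also appear with an amine, a methoxy group or a carboxylic acid on the same carbon. They also leave open how a longer chain on the carbonyl carbon would compare with compound 1 and compound 4, and where the benzoyl and 4-chlorophenyl amides stand relative to these small amides.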